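A few compounds are considered here, and "the series" means these few. Any claim that something is new, unique, unknown or untested is made for them only; others in the source may bear on it.

Compound 2 `CNC(=O)N1CCCc2ccc(NC(=O)c3cccc(-c4ccccc4)c3)cc21` has the lowest number of the three measured compounds in a functional assay on MV4-11 cells (Homo sapiens) for antiproliferative activity, with a stated time of 6 days, tested at 1.56 uM; on this read-out lower numbers stand for a weaker effect and higher numbers for a stronger effect at the one concentration tested. Compound 2 gives 2.83%. Compound 1 `CNC(=O)N1CCCc2ccc(NC(=O)c3cccc(-c4ccn(C)n4)c3)cc21` gives 70.5%, and compound 3 `CNC(=O)N1CCCc2ccc(NC(=O)c3ccc(-c4ccn(C)n4)cc3)cc21` gives 72.2%. Among the compounds with values here, the only measured step that changes the same place is a number 67.7 percentage points lower from compound 1 to compound 2 (beyond the scatter), a large drop on replacing the five-membered ring with a plain phenyl.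

Compound 4 `CNC(=O)N1CCCc2ccc(NC(=O)c3cccc(-c4cnn(C)c4)c3)cc21` has not yet been measured. It differs from compound 2 by 1-methyl-1H-pyrazol-4-yl in place of phenyl on an aromatic carbon. The entering group is again a methyl-bearing pyrazole, but joined through a different ring carbon than in compound 1, so the step from compound 1 to compound 2 bears on it only indirectly: it shows that swapping phenyl for a pyrazole at this place can move this assay a long way. Within the data shown here, no measured pair tells whether the new attachment point matters. The expected step is therefore a rise, estimated as a number 55.2 percentage points higher from compound 2 to compound 4 (beyond the scatter). Compound 4 is expected to give about 58%, within 20% to 85%.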

Compound 4, a percentage reported as inhibition, at one concentration (the size of the read-out at that concentration, not a potency): 71.2%
Estimate against measurement, compound 4: 13.2 percentage points below; the measured number falls inside the stated range.
By their numbers in this assay, from the lowest: compound 2; then compounds 1, 4 and 3 (each within the scatter of the next).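

In this assay, the step of a number 68.4 percentage points higher from compound 2 to compound 4 (beyond the scatter) shows that a second methyl-bearing pyrazole also stands far apart from phenyl at this place, so the gap is not confined to the group in compound 1. Changing only the ring carbon through which the pyrazole is joined gives a number 0.7 percentage points higher from compound 1 to compound 4 (within the scatter), so the 1-methyl-1H-pyrazol-3-yl and 1-methyl-1H-pyrazol-4-yl groups cannot be told apart at this one concentration. Nothing measured here explains why either pyrazole differs so much from phenyl.

On these data alone, whether the same holds for a pyrazole without its methyl group, or for a pyridine or thiazole ring, remains open. So does the effect of moving the 1-methyl-1H-pyrazol-4-yl group to the ring position held by the pyrazole in compound 3.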